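Cyclopentylamino for cyclohexyloxy: expected tolerance in cells

This account rests on a few compounds, and the source may have more. Where it says the series, first, only, none or still open, it means among the compounds named here.

Measured compounds:
compound 1 `Cc1cnc(Nc2ccc(C#N)cc2)nc1OC1CCCCC1` with 31200 nM
compound 2 `N#Cc1ccc(Nc2nccc(OC3CCCCC3)n2)cc1` with 322000 nM
compound 3 `Cc1cc(SC2CCCCC2)nc(Nc2ccc(C#N)cc2)n1` with >= 192000 nM

In an ADME assay on MT4 cells (Homo sapiens) for cytotoxicity, read by MTT assay (a higher number here means that more compound is tolerated, a lower number that less compound is tolerated), compound 1 gives 31200 nM, the lowest of the two numbers shown. The nearest is compound 2 with 322000 nM. The result of compound 3, >= 192000 nM, is a limit of the assay and not a number. Going by the values given here, the one measured step, a 10-fold higher number from compound 1 to compound 2 (1.01 log units; beyond the scatter), concerns removal of a methyl group and leaves the cyclohexyloxy group untouched. Compound 4 `Cc1cnc(Nc2ccc(C#N)cc2)nc1NC1CCCC1` differs from compound 1 by cyclopentylamino in place of cyclohexyloxy on an aromatic carbon. Among the compounds with values here, no measured step bears on this change, so no step beyond the scatter is expected. Compound 4 is estimated at 40000 nM, within 12000 nM to 150000 nM. This estimate means an expected 1.3-fold higher number from compound 1 to compound 4 (0.11 log units; within the scatter).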

Compound 4, half-maximal cytotoxic concentration: 170 nM
Compound 4: the middle estimate sits 240-fold (2.37 log units) above what was measured, outside the stated range (below it).
By their numbers in this assay, from the lowest: compound 4; then compound 1; then compound 2.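

In this assay, cyclopentylamino in place of cyclohexyloxy gives a 180-fold lower number from compound 1 to compound 4 (2.26 log units; beyond the scatter). The earlier step changed only the methyl group, whereas this result shows that the group on this aromatic carbon, next to the ring nitrogen, can by itself shift the tolerated concentration strongly downward. Nothing measured here explains the step.

The change alters the ring size and the linking atom together, and the compounds shown do not separate the two. Cyclohexylamino and cyclopentyloxy groups at this position would tell them apart.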